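The source may hold more compounds than are shown below. What is called first, only, known or untested is meant among the compounds shown, and "the series" means these compounds.

Working notes on the series. In an ADME assay on Vero cells (Chlorocebus sabaeus) for cytotoxicity, read by MTT assay, tested at 25 uM (on this read-out lower numbers stand for a stronger effect and higher numbers for a weaker effect at the one concentration tested), compound 1 `CSc1ccc(C(=O)/C(=C/c2cccnc2)c2ccc(Cl)c(Cl)c2)cc1` gives 95.7%, compound 2 `CCOC(=O)C(C(=O)c1ccc(OC)cc1)C(NC(C)=O)c1ccc(C(C)C)cc1` gives 98.8% and compound 3 `CCOC(=O)C(C(=O)c1ccc(OC)cc1)C(NC(C)=O)c1ccc(C(C)(C)C)cc1` gives 94.5%; compound 3 holds the lowest of the three numbers, yet all three lie within the scatter of one another, so no order among them is claimed. For the measured compounds named here, the single step with one change, a number 4.3 percentage points lower from compound 2 to compound 3 (within the scatter), is the only one that bears on the next move. Compound 4 `CCOC(=O)C(C(=O)c1ccc(OC)cc1)C(NC(C)=O)c1cccc2ccccc12` differs from compound 3 by naphthalen-1-yl in place of 4-(tert-butyl)phenyl on a saturated chain carbon bound to an amide-type nitrogen and a saturated chain carbon. Going by the values given here, because the one measured step of a number 4.3 percentage points lower from compound 2 to compound 3 (within the scatter) stayed within the scatter, no step beyond the scatter is expected here either. Compound 4 is therefore expected to give 93%, between 80% and 100%, an expected step of a number 1.5 percentage points lower from compound 3 to compound 4 (within the scatter).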

Compound 4, a percentage reported as activity, at one concentration (the size of the read-out at that concentration, not a potency): 99.2%
For compound 4 the middle estimate is 6.2 percentage points below the measured one; the measured number falls inside the stated range.
By their numbers in this assay, from the lowest: compounds 3, 1, 2 and 4 (each within the scatter of the next).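

In this assay, a second six-membered aromatic ring of carbon only enters at the saturated chain carbon bound to an amide-type nitrogen and a saturated chain carbon, giving a number 4.7 percentage points higher from compound 3 to compound 4 (within the scatter) and a number 0.4 percentage points higher from compound 2 to compound 4 (within the scatter). For the compounds shown here, the earlier step changed only the alkyl group on the phenyl ring, whereas this change replaces that group and ring with naphthalen-1-yl, and still no step lies beyond the scatter. No supporting measurement bears on the reason for this result. On these data alone, whether an amine or a carboxylic acid at this place would give a step beyond the scatter remains open.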